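Butoxy oxime series on the shared core: compound 4 outlook

A few compounds are considered here, and "the series" means these few. Any claim that something is new, unique, unknown or untested is made for them only; others in the source may bear on it.

Measured so far:
compound 1 `CCCCO/N=C/c1c(N)ncnc1Oc1ccc2[nH]c(C)cc2c1F`, 1000 nM
compound 2 `Cc1cc2c(F)c(Oc3ncnc(N)c3/C=N/O)ccc2[nH]1`, 1140 nM
compound 3 `COCCO/N=C/c1c(N)ncnc1Oc1ccc2[nH]c(C)cc2c1F`, 387 nM

All three numbers come from a functional assay on HCT-116 cells (Homo sapiens) for antiproliferative activity; on this read-out lower numbers stand for stronger inhibition and higher numbers for weaker inhibition. Compound 1 stands second highest of the three; its nearest neighbour is compound 2, a 1.1-fold higher number from compound 1 to compound 2 (0.06 log units; within the scatter), and its furthest is compound 3, a 2.6-fold lower number from compound 1 to compound 3 (0.41 log units; beyond the scatter). The remaining pair gives a 2.9-fold lower number from compound 2 to compound 3 (0.47 log units; beyond the scatter).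

Compound 4 `CNCCO/N=C/c1c(N)ncnc1Oc1ccc2[nH]c(C)cc2c1F` is not yet measured. Compared with compound 1 it differs as follows: methylamino in place of ethyl on a saturated chain carbon, two bonds along the chain from an oxygen on an unsaturated carbon.

Among the measured compounds shown here, the step that bears most directly on this change is the one from compound 1 to compound 3, where a methoxy in place of ethyl at the same place gave a 2.6-fold lower number from compound 1 to compound 3 (0.41 log units; beyond the scatter). The step from compound 2 to compound 3 points the same way, a 2.9-fold lower number from compound 2 to compound 3 (0.47 log units; beyond the scatter). For the measured compounds named here, no compound with a nitrogen at this place has been measured, so the size of the effect is uncertain. For compound 4 a modest improvement is expected, a 2.2-fold lower number from compound 1 to compound 4 (0.35 log units; beyond the scatter), giving an estimated 450 nM with a range from 150 nM to 1300 nM in this assay.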

Compound 4, half-maximal inhibitory concentration: 3010 nM
For compound 4 the middle estimate is 6.7-fold (0.83 log units) below the measured one, and the stated range ends below it.
By their numbers in this assay, from the lowest: compound 3; then compounds 1 and 2 (each within the scatter of the next); then compound 4.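

Working notes on the chain end, read in this assay: methylamino in place of ethyl on the saturated chain carbon moves the number up (a 3.0-fold higher number from compound 1 to compound 4 (0.48 log units; beyond the scatter)), whereas methoxy at the same place moved it down (a 2.6-fold lower number from compound 1 to compound 3 (0.41 log units; beyond the scatter)), so this position does not respond to every replacement of ethyl in the same direction. The two entering groups are also separated directly (a 7.8-fold higher number from compound 3 to compound 4 (0.89 log units; beyond the scatter)), and the 2-(methylamino)ethyl chain on the oxygen stands apart from the bare oxime as well (a 2.6-fold higher number from compound 2 to compound 4 (0.42 log units; beyond the scatter)), showing that the identity of the chain end matters here. Nothing available bears on why the two replacements part ways.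

Still open, as far as these compounds go, is whether the rise follows the nitrogen itself or its hydrogen, which a dimethylamino or a hydroxy group at this place could help separate. From the compounds shown here alone, how a longer chain carrying the same methylamino group would read also remains unknown.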